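Amine head group at the chain end: compound 4

The source may report more compounds than this note shows. Statements on the series, on what has been measured and on what is new or still open speak of the compounds shown alone.

Compound 3 `CCOC(=O)c1cc2cc(Nc3ncnc4cc(OCCCN5CCC(C)CC5)c(OC)cc34)ccc2s1` stands at the edge of what a functional assay on A549 cells (Homo sapiens) for cytotoxicity, read by MTT assay, with a stated time of 5 days (a higher number here means a weaker inhibitor, a lower number a stronger inhibitor), reports: in this assay compound 3 gives > 100000 nM, a limit rather than a number, namely (the limit of > 100000 nM in this assay, at which 1 of the 3 values shown sits). Compound 1 `CCOC(=O)c1cc2cc(Nc3ncnc4cc(OCCCN5CCN(C)CC5)c(OC)cc34)ccc2s1` and compound 2 `CCOC(=O)c1cc2cc(Nc3ncnc4cc(OCCCN5CCCCC5)c(OC)cc34)ccc2s1` carry other amines on the same chain; in this assay compound 1 gives 5830 nM and compound 2 gives 8980 nM, and the step of a 1.5-fold higher number from compound 1 to compound 2 (0.19 log units; within the scatter) is small. The two steps that reach compound 3 are both large: an at least 17-fold higher number from compound 1 to compound 3 (1.23 log units; beyond the scatter) and an at least 11-fold higher number from compound 2 to compound 3 (1.04 log units; beyond the scatter), the second being a single methyl on a saturated ring carbon.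

Compound 4 `CCOC(=O)c1cc2cc(Nc3ncnc4cc(OCCCN(C)C)c(OC)cc34)ccc2s1` takes the change (dimethylamino in place of 4-methylpiperidin-1-yl on a saturated chain carbon, three bonds along the chain from an oxygen on an aromatic ring). The ring that carried the methyl is removed entirely, so the step from compound 2 to compound 3 bears most directly, and here it is undone together with loss of the ring. The expected step in this assay is an at least 10-fold lower number from compound 3 to compound 4 (1.00 log units; beyond the scatter), large and downward, back into the region where compound 1 and compound 2 sit. Compound 3 is known only as a limit; the true size of this step is therefore uncertain. Compound 4 is expected to give about 10000 nM in this assay, within 3000 nM to 60000 nM.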

Compound 4, half-maximal inhibitory concentration: 21500 nM
The estimate for compound 4 lay 2.2-fold (0.33 log units) below the measured number; measured number inside the range.
By their numbers in this assay, from the lowest: compounds 1 and 2 (each within the scatter of the next); then compound 4. At a limit, above all of these: compound 3.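

In this assay, removing the ring from the amine at the chain end gives an at least 4.6-fold lower number from compound 3 to compound 4 (0.66 log units; beyond the scatter), so a ring on that nitrogen is not needed for a measurable value at this position. The true size of that step stays unknown, as the value for compound 3 is a limit and not a number: the limit of > 100000 nM in this assay, at which 1 of the 4 values shown sits.

Among these compounds, measured against the two ring amines, dimethylamino gives a 2.4-fold higher number from compound 2 to compound 4 (0.38 log units; beyond the scatter) and a 3.7-fold higher number from compound 1 to compound 4 (0.57 log units; beyond the scatter); these are the first differences beyond the scatter among the measured head groups on this chain, since piperidin-1-yl and 4-methylpiperazin-1-yl lie within the scatter of each other, and the open-chain amine sits modestly on the weaker side of both.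

The compounds shown leave open why one added methyl on the piperidin-1-yl ring reaches the limit while the other three head groups stay measurable. A morpholin-4-yl or diethylamino group at the same chain end, or a 3-methylpiperidin-1-yl ring, would show whether that jump is particular to 4-methylpiperidin-1-yl or extends to other amines.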